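This account rests on a few compounds, and the source may have more. Where it says the series, first, only, none or still open, it means among the compounds named here.

Measured so far:
- compound 1, `C=CCn1c(=O)/c(=C\c2ccc(F)c(Br)c2)[nH]c(=O)/c1=C\c1ccccc1OC`: "not active" (no number reported)
- compound 2, `C=CCn1c(=O)/c(=C\c2ccccc2F)[nH]c(=O)/c1=C\c1ccccc1OC`: 5600 nM

Both compounds were run in a functional assay on K562 cells (Homo sapiens) for cytotoxicity, read by CCK-8 assay, with a stated time of 72 h; on this read-out lower numbers stand for stronger inhibition and higher numbers for weaker inhibition. Among the measured compounds shown here, compound 1 is reported as "not active" (no number reported) with no number attached, so compound 2 gives the only number in this assay, namely 5600 nM; it therefore stands alone as the reference point for the series, with nothing to rank it against.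

Compound 3, `C=CCn1c(=O)/c(=C\c2ccccc2C(F)(F)F)[nH]c(=O)/c1=C\c1ccccc1OC`, has not yet been measured. It differs from compound 2 in one place:

trifluoromethyl in place of fluoro on an aromatic carbon

For the measured compounds named here, no step between two measured compounds is available, so the size of this change cannot be read from the data. The only other entry, compound 1, carries different groups on the same ring and gives no number, which leaves the direction open. The expectation is a step of roughly the usual scatter or a little beyond, more likely toward weaker inhibition, a 1.4-fold higher number from compound 2 to compound 3 (0.15 log units; within the scatter).

Compound 3 is therefore estimated at 8000 nM in this assay, with a range from 2500 nM to 25000 nM.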

Compound 3, half-maximal inhibitory concentration: 2700 nM
Beside the measured number, compound 3's estimate is 3.0-fold (0.47 log units) above it; low and high end bracket the measured number.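

In this assay, the series now has its first readable step: trifluoromethyl in place of fluoro on an aromatic carbon, ortho to a large group, gives a 2.1-fold lower number from compound 2 to compound 3 (0.32 log units; beyond the scatter). This position therefore accepts a group of four heavy atoms in place of a single one without loss in this read-out, and the modest change is toward stronger inhibition. No measurement at hand bears on why the number moves this way.

From the compounds shown here alone, this single pair gives only two points at this carbon, so it remains open whether a chlorine, a methyl, a methoxy or a nitrile there would give a number near those of compound 2 and compound 3, or whether the same carbon would accept an amine or a carboxylic acid. Going by these compounds, compound 1 differs from both in more than one place and offers no direct comparison, so it also remains open whether the step holds with other substituents on the same ring or with a longer chain in place of the allyl group on the shared core.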